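The compounds below may be only part of what the source reports. "The series", "measured", "known", "first", "only" and "open" are said of these compounds alone.

Measured compounds:
- compound 1, `C#CCOc1ccc(-c2cc(-c3ccc(OCC#C)cc3)nc(-c3ccccc3)n2)cc1`, gives 25600 nM in an assay on BTI-TN-5B1-4 cells for inhibition of Amine oxidase [flavin-containing] A (Homo sapiens), read by fluorescence and Amplex Red, using microsomes, with a stated time of 30 min; on this read-out lower numbers stand for stronger inhibition and higher numbers for weaker inhibition
- compound 2, `C#CCOc1ccc(-c2cc(-c3ccc(OCC#C)c(OC)c3)nc(N)n2)cc1`, is reported as "not active" (no number reported) in this assay
- compound 3, `C#CCOc1ccc(-c2cc(-c3ccc(OCC#C)c(OC)c3)nc(C)n2)cc1`, gives 25000 nM in this assay

All three compounds share one core and sit at the weak end of what this assay can read; compound 2 has no single number at all, only a report that nothing measurable was seen. Compound 4, `C#CCOc1ccc(-c2cc(-c3ccc(OCC#C)cc3)nc(N)n2)cc1`, differs from compound 2 in one place: hydrogen in place of methoxy on an aromatic carbon. Nothing measured here shows what such a change does, so the expected step in this assay is small and of unknown direction, most likely none beyond the scatter. Compound 4 is therefore expected to come out at about 40000 nM, within a range of 15000 nM to 100000 nM, with a fair chance that no number is reported.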

Compound 4, half-maximal inhibitory concentration: 32100 nM
For compound 4 the middle estimate is 1.2-fold (0.10 log units) above the measured one; the measured number falls inside the stated range.
By their numbers in this assay, from the lowest: compounds 3, 1 and 4 (each within the scatter of the next).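

In this assay, compound 2 is reported as "not active", while compound 4, with hydrogen in place of methoxy ortho to the propargyloxy group, gives 32100 nM; with no number for compound 2, the size of this step cannot be read. Amino in place of phenyl on an aromatic carbon gives a 1.3-fold higher number from compound 1 to compound 4 (0.10 log units; within the scatter), so these two groups are not told apart at this position. No measured evidence bears on why these results came out as they did.

Going by these compounds, whether a carboxylic acid or a dimethylamino group at this position would give a number beyond the scatter remains open.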